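The source may report more compounds than this note shows. Statements on the series, on what has been measured and on what is new or still open speak of the compounds shown alone.

Three compounds sharing the same basic design were tested in a functional assay on HepG2 cells (Homo sapiens) for antiproliferative activity, read by MTT assay, with a stated time of 24 h; on this read-out lower numbers stand for stronger inhibition and higher numbers for weaker inhibition. Compound 1 `O=c1[nH]cc(S(=O)(=O)Nc2ccccc2-c2cn(-c3cccc(F)c3)nn2)c(=O)[nH]1` carries a 3-fluorophenyl on an aromatic nitrogen. In this assay compound 1 reaches only the limit > 20000 nM. Compound 2 `O=c1[nH]cc(S(=O)(=O)Nc2ccccc2-c2cn(-c3ccc(F)cc3)nn2)c(=O)[nH]1` differs from it by 4-fluorophenyl in place of 3-fluorophenyl on an aromatic nitrogen. In this assay compound 2 also stops at the limit > 20000 nM. The step between them, a step that the two limits leave unreadable from compound 1 to compound 2, cannot be sized because the limit of > 20000 nM in this assay, at which 3 of the 3 values shown sit, is where both values sit. Compound 3 `O=c1[nH]cc(S(=O)(=O)Nc2ccc(-c3cn(-c4cccc(F)c4)nn3)cc2)c(=O)[nH]1` has a different core; the difference between the two cores is not broken down here. In this assay compound 3 likewise gives only the limit > 20000 nM. Compound 4 `O=c1[nH]cc(S(=O)(=O)Nc2ccc(-c3cn(-c4ccc(F)cc4)nn3)cc2)c(=O)[nH]1` has not yet been measured; it differs from compound 3 by 4-fluorophenyl in place of 3-fluorophenyl on an aromatic nitrogen, the same change as that between compound 1 and compound 2. Since every value gathered so far sits at the limit of > 20000 nM in this assay, at which 3 of the 3 values shown sit, the step is expected to be a step that the limit leaves unreadable from compound 3 to compound 4, with no sign that it would become readable. Compound 4 is therefore expected to come out near 30000 nM, most probably again only as a limit, somewhere between 15000 nM and 100000 nM.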

Compound 4, half-maximal inhibitory concentration: > 20000 nM
Compound 4: a limit, no number; the forecaster's own chance of this, stated with the estimate: 90%; the middle value lies beyond the limit too.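

Compound 3 and compound 4 give no number to compare, so the change from 3-fluorophenyl to 4-fluorophenyl between them has no readable size, because both stop at a limit: the limit of > 20000 nM in this assay, at which 4 of the 4 values shown sit. The compounds shown leave open whether this change, or the different core, has any effect on activity in this assay beyond that limit.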